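Swapping the tert-butyl end for a methoxy end

The source may report more compounds than this note shows. Statements on the series, on what has been measured and on what is new or still open speak of the compounds shown alone.

In an ADME assay on microsomes from liver (Mus musculus) for metabolic stability, tested at 5 uM (a higher number here means that the compound lasts longer, a lower number that the compound disappears faster), compound 1 `CCCCCCCCNc1ccc(C(=O)O)cc1S(=O)(=O)NC` gives 0.2 h as its half-life, which is a measured number. Compound 2 `CN(C)S(=O)(=O)c1cc(C(=O)O)ccc1NCCC(C)(C)C` reads > 1 h in this assay and that reading is a limit of the assay, not a number. Compound 3 `COCCCCNc1ccc(C(=O)O)cc1S(=O)(=O)N(C)C` differs from compound 2 in one place: 2-methoxyethyl in place of tert-butyl on a saturated chain carbon, two bonds along the chain from a nitrogen on an aromatic ring so that (3,3-dimethylbutyl)amino becomes (4-methoxybutyl)amino. Within the data shown here, no measured pair shows this change alone, so its size cannot be read directly. Compound 1 at 0.2 h shows that a member of this series can disappear quickly, so a fall beyond the usual scatter is expected rather than no change. The expected move is an at least 2.0-fold lower number from compound 2 to compound 3 (0.30 log units; that floor lies within the scatter) on this estimate. For compound 3 the estimated half-life is 0.5 h with an expected range of 0.2 h to 1 h in this assay once it is measured.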

Compound 3, half-life: > 1 h
Compound 3: a limit, no number (the forecaster's own chance of this, stated with the estimate: 20%); middle value at least 2.0-fold (0.30 log units) from the limit.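

Compound 3 reads > 1 h in this assay, which is a limit and not a number. Among these compounds, no step from compound 2 to compound 3 can be read, because both compounds stop at the same point: the limit of > 1 h in this assay, at which 2 of the 3 values shown sit. Going by these compounds, how far either half-life extends past that limit stays open, and so does whether 2-methoxyethyl in place of tert-butyl changes it at all.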